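The compounds below may be only part of what the source reports. "The series", "measured", "known", "first", "only" and "open" are said of these compounds alone.

Measured so far:
- compound 1 `O=C(O)c1cc(-c2cccc(COc3ccc4c(c3)CN(c3ccccc3)C4=O)c2)ccc1Cl`: 260 nM
- compound 2 `CC(C)N1Cc2cc(OCc3cccc(-c4ccc(Cl)c(C(=O)O)c4)c3)ccc2C1=O`: 70 nM

Both compounds were tested in an assay on HEK293 cells for positive allosteric modulation of metabotropic glutamate receptor 2 (Rattus norvegicus), read by thallium flux; a lower number here means that less compound is needed, a higher number that more compound is needed for the effect. Going by the values given here, compound 2 has the lowest of the two numbers; its only neighbour is compound 1, and the step of a 3.7-fold lower number from compound 1 to compound 2 (0.57 log units; beyond the scatter) tells how far apart they lie. The new compound 3 `O=C(O)c1cc(-c2cccc(COc3ccc4c(c3)CN(C3CCC3)C4=O)c2)ccc1Cl` is compound 2 with one change: cyclobutyl in place of isopropyl on an amide-type nitrogen in a ring. Among the compounds with values here, the only measured step at this position is a 3.7-fold lower number from compound 1 to compound 2 (0.57 log units; beyond the scatter), which swaps a flat aromatic ring for a small branched chain. Cyclobutyl is a small saturated ring of about the same bulk as isopropyl, and no measured pair separates two such small groups from one another, so the change from compound 2 to compound 3 is expected to stay within the usual scatter, with at most a slight move toward a lower number. Compound 3 is therefore estimated at 55 nM in this assay, with a range of 20 nM to 150 nM, meaning an expected step of a 1.3-fold lower number from compound 2 to compound 3 (0.10 log units; within the scatter).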

Compound 3, half-maximal effective concentration: 90 nM
Compound 3: the middle estimate sits 1.6-fold (0.21 log units) below what was measured; measured number inside the range.
By their numbers in this assay, from the lowest: compounds 2 and 3 (each within the scatter of the next); then compound 1.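

In this assay, the change from isopropyl to cyclobutyl gives a 1.3-fold higher number from compound 2 to compound 3 (0.11 log units; within the scatter), so on this amide-type nitrogen the branched group and the four-membered carbon ring cannot be told apart. Measured against phenyl, cyclobutyl gives a 2.9-fold lower number from compound 1 to compound 3 (0.46 log units; beyond the scatter), which shows that the lower number is shared by a second non-aromatic group and that a ring on this nitrogen does not by itself bring the higher number of compound 1. Nothing available explains why these groups compare as they do.

Still open, on these data alone, is whether the number stays in this range with methyl, with cyclohexyl or with a longer chain such as n-butyl on this nitrogen. As far as these compounds go, it is also open how a group carrying an amine or an ether oxygen would fare at this position.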